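Compound 3 against the limits of the series

The source may hold more compounds than are shown below. What is called first, only, known or untested is meant among the compounds shown, and "the series" means these compounds.

compound 1 `Nc1cc(N)c2nc(-c3ccccc3)c(NCc3ccc(F)cc3)nc2c1`: < 100000 nM
compound 2 `COc1ccc(CNc2nc3cc(N)cc(N)c3nc2-c2ccccc2)cc1`: < 100000 nM

Both values in a functional assay on 786-0 cells (Homo sapiens) for inhibition, read by sulforhodamine B assay, with a stated time of 48 h (on this read-out higher numbers stand for lower toxicity in this test and lower numbers for higher toxicity in this test), are limits of the assay, not numbers. Compound 1 stands at that limit with < 100000 nM. Going by the values given here, the single measured step, a step that the two limits leave unreadable from compound 1 to compound 2, is unreadable, as both ends rest on (the limit of < 100000 nM in this assay, at which 2 of the 2 values shown sit).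

Compound 3 `Nc1cc(N)c2nc(-c3ccccc3)c(Sc3ccc(Cl)c(Cl)c3)nc2c1` differs from compound 1 by (3,4-dichlorophenyl)sulfanyl in place of (4-fluorobenzyl)amino on an aromatic carbon. Among the compounds with values here, no measured step bears on this change, so neither direction nor size can be read from the series. The expected step that the limit leaves unreadable from compound 1 to compound 3 is therefore set near zero, with wide uncertainty. Compound 3 is expected to give 30000 nM, within 5000 nM to 100000 nM.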

Compound 3, concentration lethal to 50% of the cells: < 100000 nM
Compound 3: only a limit was reported (the forecaster's own chance of this, stated with the estimate: 40%); the middle value is on the limit's open side.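

No new step can be read between compound 1 and compound 3 in this assay because both values are limits: the limit of < 100000 nM in this assay, at which 3 of the 3 values shown sit.
From the compounds shown here alone, whether (3,4-dichlorophenyl)sulfanyl in place of (4-fluorobenzyl)amino changes this read-out at all, and in which direction, stays open.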